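Moving a trifluoromethyl group on the phenyl ring

The source may report more compounds than this note shows. Statements on the series, on what has been measured and on what is new or still open speak of the compounds shown alone.

Measured values in an ADME assay on L6 cells (Rattus norvegicus) for cytotoxicity, read by resazurin assay, with a stated time of 70 h (a higher number here means a weaker inhibitor, a lower number a stronger inhibitor), for three compounds
- Compound 1 `COc1cc(NC(C)CCCNC(=O)NNC(=O)NCCCO)c2ncccc2c1` gives "not determined" (no result reported)
- Compound 2 `COc1cc(NC(C)CCCNC(=O)NNC(=O)Nc2ccc(Cl)cc2)c2ncccc2c1` gives 91900 nM
- Compound 3 `COc1cc(NC(C)CCCNC(=O)NNC(=O)Nc2cccc(C(F)(F)F)c2)c2ncccc2c1` gives 32100 nM

Compound 3 has the lower of the two numbers (32100 nM). Compound 1 offers no number for comparison. Compound 4 `COc1cc(NC(C)CCCNC(=O)NNC(=O)Nc2ccc(C(F)(F)F)cc2)c2ncccc2c1` carries 4-(trifluoromethyl)phenyl in place of 3-(trifluoromethyl)phenyl on an amide-type nitrogen and awaits measurement in this assay as the next test. For the measured compounds named here, only one measured step bears on this change, and only loosely: a 2.9-fold lower number from compound 2 to compound 3 (0.46 log units; beyond the scatter) is modest, though beyond the scatter, and it replaced 4-chlorophenyl. Going by the values given here, a small rise, no larger than that step, is therefore expected (a 1.4-fold higher number from compound 3 to compound 4 (0.15 log units; within the scatter)). For compound 4 the estimate is 45000 nM in a range from 20000 nM to 100000 nM as expected bounds.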

Compound 4, half-maximal inhibitory concentration: 14900 nM
Beside the measured number, compound 4's estimate is 3.0-fold (0.48 log units) above it; measured number outside the range, below it.
By their numbers in this assay, from the lowest: compound 4; then compound 3; then compound 2.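

In this assay moving the trifluoromethyl group alone gives a 2.2-fold lower number from compound 3 to compound 4 (0.33 log units; beyond the scatter) even though the atoms stay the same. Trifluoromethyl in place of chloro on an aromatic carbon gives a 6.2-fold lower number from compound 2 to compound 4 (0.79 log units; beyond the scatter) as a separate step, so the earlier comparison had mixed two changes, each of which moves the number. Nothing available here accounts for either step. The compounds shown leave open whether a nitrile or a methoxy group in place of that trifluoromethyl would lower the number further. An amine on the same carbon also remains an open case.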